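This account rests on a few compounds, and the source may have more. Where it says the series, first, only, none or still open, it means among the compounds named here.

Working notes on the series. Compound 1 `Cc1ccc2[nH]c(C(=O)N[C@H]3CN(S(=O)(=O)c4ccccc4)C[C@@H]3C(=O)NCCN(C)C)cc2c1` is the reference point here; in a functional assay on HEK293 cells for agonist activity at growth hormone secretagogue receptor type 1 (Homo sapiens), read by HTRF and inositol phosphate accumulation, with a stated time of 90 min, in the presence of a further agent that is not named here (on this read-out higher numbers stand for larger maximal responses and lower numbers for smaller maximal responses), compound 1 gives 93%, the highest of the two numbers in hand. Its mirror image, compound 2 `Cc1ccc2[nH]c(C(=O)N[C@@H]3CN(S(=O)(=O)c4ccccc4)C[C@H]3C(=O)NCCN(C)C)cc2c1`, gives 79% in this assay, a step of a number 14 percentage points lower from compound 1 to compound 2 (beyond the scatter). The only thing separating the two is the fact that compounds 1 and 2 differ only in the configuration as drawn, so this step speaks to the configuration of the core and to nothing else.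

Compound 3 `Cc1ccc2[nH]c(C(=O)N[C@H]3CN(S(=O)(=O)c4ccccc4)C[C@@H]3C(=O)NC[C@H]3CCCN3)cc2c1` keeps the configuration of compound 1 at both ring stereocentres and changes the chain on the amide instead: pyrrolidin-2-yl in place of (dimethylamino)methyl on a saturated chain carbon bound to an amide-type nitrogen. Going by the values given here, no measured step touches this part of the molecule, so the inversion step cannot be carried over; it only shows that the configuration of compound 1, which compound 3 shares, is the one giving the larger maximal response. Among the compounds with values here, with no measured precedent for exchanging the terminal amine, the expected step of a number 5 percentage points lower from compound 1 to compound 3 (within the scatter) in this assay is small, within or near the scatter, and compound 3 is estimated at 88%, with a range from 70% to 102%.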

Compound 3, largest response reached (Emax), in percent of the reference or control that the assay uses: 94%
For compound 3 the middle estimate is 6 percentage points below the measured one; the measured number falls inside the stated range.
By their numbers in this assay, from the lowest: compound 2; then compounds 1 and 3 (each within the scatter of the next).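

In this assay the exchange at this position, on a saturated chain carbon bound to an amide-type nitrogen, gives a number 1 percentage points higher from compound 1 to compound 3 (within the scatter) and so shows what the inversion step could not: the terminal amine can be changed without a maximal response that can be told apart from that of compound 1. With the configuration of the shared core held, this position takes pyrrolidin-2-yl, with its five-membered non-aromatic ring, its hydrogen-bond donor and its further defined stereocentre, in place of (dimethylamino)methyl. Going by these compounds alone, the only available evidence concerns the configuration of the core, so nothing here gives a cause for this step.

The compounds shown leave open whether the opposite configuration at the pyrrolidin-2-yl stereocentre, a piperidin-2-yl ring, a primary amine or a carboxylic acid at the end of the chain, or a longer chain would hold the maximal response at this level. They also leave open whether inverting both ring stereocentres of compound 3 would lower the response as it does in the mirror-image pair.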